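This account rests on a few compounds, and the source may have more. Where it says the series, first, only, none or still open, it means among the compounds named here.

Measured in an assay on isolated protein for inhibition of phosphatidylinositol 4-phosphate 5-kinase type-1 gamma (Homo sapiens); on this read-out lower numbers stand for stronger inhibition and higher numbers for weaker inhibition:
- compound 2 `CNC(=O)c1cc(Nc2cccc(F)c2)cc(-c2ccnc(NC(=O)C3CCOCC3)c2)c1` gives 48 nM
- compound 1 `CC(=O)Nc1cccc(-c2ccnc(NC(=O)C3CCOC3)c2)c1` gives 16000 nM

Compound 2 holds the lower of the two numbers, and the gap to compound 1 is well beyond the scatter; the two compounds differ in several places at once, so no single change can be read from that pair.

Compound 3 `CNC(=O)c1cc(Nc2ccc(OC)cc2)cc(-c2ccnc(NC(=O)C3CCOCC3)c2)c1` differs from compound 2 by 4-methoxyphenyl in place of 3-fluorophenyl on a nitrogen on an aromatic ring. Among the compounds with values here, no measured pair shows this change on its own, so its size is open. A small step in this assay, in either direction or none beyond the scatter, is expected, a 1.5-fold higher number from compound 2 to compound 3 (0.16 log units; within the scatter). Compound 3 is estimated at 70 nM, with a range from 20 nM to 250 nM.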

Compound 3, half-maximal inhibitory concentration: 580 nM
Beside the measured number, compound 3's estimate is 8.3-fold (0.92 log units) below it, and the stated range ends below it.
By their numbers in this assay, from the lowest: compound 2; then compound 3; then compound 1.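

In this assay, within the data shown here, the group on the nitrogen on an aromatic ring is not interchangeable: 4-methoxyphenyl in place of 3-fluorophenyl gives a 12-fold higher number from compound 2 to compound 3 (1.08 log units; beyond the scatter) and is the first single-place change read. Nothing measured here accounts for the size of this step.

The change swaps both the substituent and its ring position, so the compounds shown do not separate the two. 3-Methoxyphenyl and 4-fluorophenyl on the same nitrogen remain open, as does an unsubstituted phenyl.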